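Trifluoromethoxy for trifluoromethyl on a hydroxylated core

The source may report more compounds than this note shows. Statements on the series, on what has been measured and on what is new or still open speak of the compounds shown alone.

Measured compounds:
compound 1, `FC(F)(F)c1ccc(-c2ccc(-c3ccc(-c4nc5ccccc5[nH]4)cc3)cc2)cc1`, 100000 nM; compound 2, `FC(F)(F)Oc1ccc(-c2ccc(-c3ccc(-c4nc5ccccc5[nH]4)cc3)cc2)cc1`, 100000 nM; compound 3, `Oc1cccc2[nH]c(-c3ccc(-c4ccc(-c5ccc(C(F)(F)F)cc5)cc4)cc3)nc12`, 3180 nM.

All three were tested in a functional assay on DWD cells (Homo sapiens) for inhibition, read by sulforhodamine B assay; a higher number here means a weaker inhibitor of growth, a lower number a stronger inhibitor of growth. Compound 1 and compound 2 differ by trifluoromethoxy in place of trifluoromethyl on an aromatic carbon, and the step of no change at the digits printed from compound 1 to compound 2 (within the scatter). Compound 3 carries a different core than compound 1: the cores differ by hydroxy in place of hydrogen on an aromatic carbon, and this step gave a 31-fold lower number from compound 1 to compound 3 (1.50 log units; beyond the scatter), the lowest number among the three.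

Compound 4, `Oc1cccc2[nH]c(-c3ccc(-c4ccc(-c5ccc(OC(F)(F)F)cc5)cc4)cc3)nc12`, is not yet measured. It differs from compound 3 by trifluoromethoxy in place of trifluoromethyl on an aromatic carbon, the same kind of change as from compound 1 to compound 2; the two place lines read alike. That earlier step lay within the scatter. On that basis compound 4 is expected to sit close to compound 3, with a step of a 1.1-fold higher number from compound 3 to compound 4 (0.04 log units; within the scatter) in this assay. Among the compounds with values here, the estimate for compound 4 is 3500 nM, expected to fall between 1200 nM and 10000 nM; it rests on the single paired step between compound 1 and compound 2 and on the value of compound 3.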

Compound 4, concentration for 50% growth inhibition: 3100 nM
Estimate against measurement, compound 4: 1.1-fold (0.05 log units) above; the measured number falls inside the stated range.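

In this assay, trifluoromethoxy in place of trifluoromethyl on the hydroxy-bearing core gave a 1.0-fold lower number from compound 3 to compound 4 (0.01 log units; within the scatter), and this step matches the one seen on the core without the hydroxy: the same change on two cores in this assay, no change at the digits printed (within the scatter) from compound 1 to compound 2 and a 1.0-fold lower number (0.01 log units; within the scatter) from compound 3 to compound 4, 1.0-fold (0.01 log units) apart, within the scatter of two such steps

The hydroxy step also carried over with trifluoromethoxy in place, giving a 32-fold lower number from compound 2 to compound 4 (1.51 log units; beyond the scatter), which matches the step seen with trifluoromethyl: the same change on two cores in this assay, a 31-fold lower number (1.50 log units; beyond the scatter) from compound 1 to compound 3 and a 32-fold lower number (1.51 log units; beyond the scatter) from compound 2 to compound 4, 1.0-fold (0.01 log units) apart, within the scatter of two such steps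

Together, the two pairs show that in this small set the two changes act independently of each other, but they rest on only two cores and one cell assay, so they do not show that the same would hold on any other core or explain why the steps agree.

The compounds shown leave open how an amine or a carboxylic acid would compare with trifluoromethyl and trifluoromethoxy on the 4-substituted phenyl. They also leave open whether a methoxy group or an amine could take the place of the hydroxy on the core and keep the large step.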